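Compound 3 to compound 4: a benzoxazolyl swap

The source may hold more compounds than are shown below. What is called first, only, known or untested is meant among the compounds shown, and "the series" means these compounds.

Going by the values given here, in a functional assay on A549 cells (Homo sapiens) for antiproliferative activity, read by MTT assay, with a stated time of 48 h (on this read-out lower numbers stand for stronger inhibition and higher numbers for weaker inhibition), compound 3 `N#Cc1nc2c(-c3nc4ccccc4[nH]3)c(N)n(CCCN3CCCCC3)c2nc1C#N` gives 6110 nM, the only number among the three measured compounds. Compound 1 `Cn1c(N)c(-c2nc3ccccc3[nH]2)c2nc(C#N)c(C#N)nc21` gives > 50000 nM, which is a limit of the assay and not a number. Compound 2 `N#Cc1nc2c(-c3nc4ccccc4[nH]3)c(N)n(CCN3CCCC3)c2nc1C#N` gives > 50000 nM, again only a limit.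

Compound 4 `N#Cc1nc2c(-c3nc4ccccc4o3)c(N)n(CCCN3CCCCC3)c2nc1C#N` keeps the 3-(piperidin-1-yl)propyl group of compound 3 and carries 1,3-benzoxazol-2-yl in place of 1H-benzimidazol-2-yl on an aromatic carbon.

The measured steps bear on this change only indirectly. Two can be read, an at least 8.1-fold lower number from compound 1 to compound 3 (0.91 log units; beyond the scatter) and an at least 8.1-fold lower number from compound 2 to compound 3 (0.91 log units; beyond the scatter), while the third is a step that the two limits leave unreadable from compound 1 to compound 2. All three alter the group on the ring nitrogen and leave 1H-benzimidazol-2-yl untouched, so none measures the exchange made in compound 4. The data therefore give no direction for this exchange, and no step beyond the scatter is expected in this assay, with compound 3 at 6110 nM as the anchor. The expected step is a 1.3-fold higher number from compound 3 to compound 4 (0.12 log units; within the scatter). A report of only a limit also remains possible, given (the limit of > 50000 nM in this assay, at which 2 of the 3 values shown sit).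

The estimated value for compound 4 is 8000 nM. The expected range for compound 4 runs from 2000 nM to 40000 nM.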

Compound 4, half-maximal inhibitory concentration: 8670 nM
Beside the measured number, compound 4's estimate is 1.1-fold (0.03 log units) below it; low and high end bracket the measured number.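

In this assay, the exchange on the aromatic carbon next to the ring atom that bears an amino group gives a 1.4-fold higher number from compound 3 to compound 4 (0.15 log units; within the scatter), so the two compounds cannot be ranked, and this is the first step shown at this position, since the earlier steps all altered the group on the ring nitrogen. The 1,3-benzoxazol-2-yl group has 0 hydrogen-bond donors and 2 hydrogen-bond acceptors against 1 of each in 1H-benzimidazol-2-yl, and with the 3-(piperidin-1-yl)propyl group held constant, the pair still stands within the scatter. Nothing shown gives a cause for this result.

Still open, as far as these compounds go, is whether other groups on this carbon, such as 1,3-benzothiazol-2-yl or 1-methyl-1H-benzimidazol-2-yl, would also stay within the scatter of compound 3, or would instead give a step beyond it. Also open, from the compounds shown here alone, is whether the same exchange would read alike with the methyl of compound 1 or the 2-(pyrrolidin-1-yl)ethyl of compound 2 on the ring nitrogen, or with a 3-(morpholin-4-yl)propyl group there.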